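A Fluoro Step on Compound 1

This account rests on a few compounds, and the source may have more. Where it says the series, first, only, none or still open, it means among the compounds named here.

Measured so far in a functional assay on MCF7 cells (Homo sapiens) for antiproliferative activity, read by MTT assay, with a stated time of 48 h (a higher number here means a weaker inhibitor, a lower number a stronger inhibitor), are three compounds:
- compound 1 `c1ccc(-c2nn(-c3ccccc3)cc2-c2nc3ccccc3[nH]2)cc1` gives 3190 nM
- compound 2 `Clc1ccc2[nH]c(-c3cn(-c4ccccc4)nc3-c3ccccc3)nc2c1` gives 1960 nM
- compound 3 `COc1ccc2[nH]c(-c3cn(-c4ccccc4)nc3-c3ccccc3)nc2c1` gives 1590 nM

Compound 1 has the highest of these three numbers, but both of its measured steps stay within the scatter. They are a 1.6-fold lower number from compound 1 to compound 2 (0.21 log units; within the scatter) with chloro in place of hydrogen on an aromatic carbon, and a 2.0-fold lower number from compound 1 to compound 3 (0.30 log units; within the scatter) with methoxy in place of hydrogen on an aromatic carbon.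

Compound 4 `Fc1ccc(-c2nn(-c3ccccc3)cc2-c2nc3ccccc3[nH]2)cc1` has not yet been measured. Its difference from compound 1 is fluoro in place of hydrogen on an aromatic carbon and amounts to fluoro in place of hydrogen on an aromatic carbon, or phenyl to 4-fluorophenyl. The two measured steps change a different part of the molecule, so they offer only a loose guide. Both point to a lower number, yet neither leaves the scatter, so no step beyond the scatter is expected in this assay here. The expected step is a 1.4-fold lower number from compound 1 to compound 4 (0.14 log units; within the scatter) and no larger. Compound 4 is estimated at 2300 nM with an expected range from 1000 nM to 5000 nM in this assay once it is tested.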

Compound 4, half-maximal inhibitory concentration: 3200 nM
Beside the measured number, compound 4's estimate is 1.4-fold (0.14 log units) below it, and the stated range covers the measured number.
By their numbers in this assay, from the lowest: compounds 3, 2, 1 and 4 (each within the scatter of the next).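

In this assay, the change from phenyl to 4-fluorophenyl gives a 1.0-fold higher number from compound 1 to compound 4 (0.00 log units; within the scatter), so compound 1 and compound 4 cannot be told apart. Within the data shown here, this is the first view of this position, on a six-membered aromatic ring of carbon only and para to a large group, and swapping hydrogen for one fluorine atom there leaves no readable mark on the antiproliferative result. The chloro and methoxy steps changed a different part of the molecule, and no measurement shown here offers an explanation for the fluoro result.

From the compounds shown here alone, whether an amine, a carboxylic acid or a longer chain at this same position would give a step beyond the scatter remains open. Also open, going by these compounds, is whether chloro or methoxy here would give the same result as on the other part of the molecule.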